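Cyano in place of methylcarbamoyl on the aromatic ring

This account rests on a few compounds, and the source may have more. Where it says the series, first, only, none or still open, it means among the compounds named here.

Compound 3 `C=CC[C@H]1C[C@]2([C@@H](C)Cc3ccc(OC)c(C(=O)NC)c3)OCOC2=CC1=O` gives the highest number among the three measured compounds in a functional assay on M14 cells (Homo sapiens) for antiproliferative activity, with a stated time of 72 h (on this read-out lower numbers stand for stronger inhibition and higher numbers for weaker inhibition), namely 1400 nM. Compound 1 `C=CC[C@H]1C[C@]2([C@@H](C)Cc3ccc(OC)c(OC)c3)OCOC2=CC1=O` gives 110 nM in this assay, and compound 2 `C=CC[C@H]1C[C@]2([C@@H](C)Cc3ccc(OC)c(C)c3)OCOC2=CC1=O` gives 410 nM. The step from compound 3 to compound 4 `C=CC[C@H]1C[C@]2([C@@H](C)Cc3ccc(OC)c(C#N)c3)OCOC2=CC1=O` is cyano in place of methylcarbamoyl on an aromatic carbon. Within the data shown here, two measured steps bear on it: a 13-fold higher number from compound 1 to compound 3 (1.10 log units; beyond the scatter) and a 3.4-fold higher number from compound 2 to compound 3 (0.53 log units; beyond the scatter), both showing that methylcarbamoyl carries the highest number of the three. Cyano is neither methoxy nor methyl, so the size of the return is uncertain, but a downward step beyond the scatter is expected. Compound 4 is therefore expected to give 500 nM in this assay, between 150 nM and 1600 nM. Expected, this amounts to a 2.8-fold lower number from compound 3 to compound 4 (0.45 log units; beyond the scatter).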

Compound 4, half-maximal inhibitory concentration: 180 nM
For compound 4 the middle estimate is 2.8-fold (0.44 log units) above the measured one; the range from low to high includes it.
By their numbers in this assay, from the lowest: compounds 1 and 4 (each within the scatter of the next); then compound 2; then compound 3.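

In this assay the position tolerates a group other than methoxy: cyano in place of methylcarbamoyl gives a 7.8-fold lower number from compound 3 to compound 4 (0.89 log units; beyond the scatter) and so recovers most of the ground lost to methylcarbamoyl. Cyano also outdoes methyl, with a 2.3-fold lower number from compound 2 to compound 4 (0.36 log units; beyond the scatter) on that change, whereas a 1.6-fold higher number from compound 1 to compound 4 (0.21 log units; within the scatter) places it level with methoxy. Nothing given here accounts for these differences.

The compounds shown leave open whether an amine, a carboxylic acid or a dimethylcarbamoyl group at this position would follow cyano or methylcarbamoyl.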